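This account rests on a few compounds, and the source may have more. Where it says the series, first, only, none or still open, it means among the compounds named here.

Measured so far in a functional assay on KB 3-1 cells (Homo sapiens) for cytotoxicity, read by MTT assay, with a stated time of 72 h; on this read-out higher numbers stand for weaker inhibition and lower numbers for stronger inhibition:
- compound 1 `O=C1Nc2ccccc2/C1=N/NC(=S)Nc1ccccc1` gives 3530 nM in this series
- compound 2 `O=C1Nc2ccccc2/C1=N/NC(=S)NCc1ccccc1` gives 11700 nM in this series
- compound 3 `O=C1Nc2ccccc2/C1=N/NC(=S)Nc1cccc(Cl)c1` gives 1870 nM in this series

The step of a 1.9-fold lower number from compound 1 to compound 3 (0.28 log units; within the scatter) stays within the scatter, so compound 3 and compound 1 share the low end of the numbers here. The step of a 6.3-fold lower number from compound 2 to compound 3 (0.80 log units; beyond the scatter) is modest and beyond the scatter.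

Next comes compound 4 `O=C1Nc2ccccc2/C1=N/NC(=S)Nc1ccc(Cl)cc1` with this change: 4-chlorophenyl in place of 3-chlorophenyl on an amide-type nitrogen and in words 4-chlorophenyl in place of 3-chlorophenyl on an amide-type nitrogen.

Among the measured compounds shown here, no measured pair compares two chlorophenyl groups, so the data give no direct measure of this move. The nearest evidence is the chloro step a 1.9-fold lower number from compound 1 to compound 3 (0.28 log units; within the scatter) and it did not leave the scatter. The step of a 3.3-fold higher number from compound 1 to compound 2 (0.52 log units; beyond the scatter) is larger, but it swaps phenyl for benzyl, and compound 4 keeps the phenyl ring attached directly to that nitrogen. A step beyond the scatter is therefore not expected.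

The expected step is a 1.1-fold higher number from compound 3 to compound 4 (0.03 log units; within the scatter) and it would leave compound 4 beside compound 3 on the numbers.

For compound 4 the estimated value is 2000 nM with an expected range from 900 nM to 4500 nM on repeat measurements.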

Compound 4, half-maximal inhibitory concentration: 13400 nM
Compound 4: middle estimate off by 6.7-fold (0.83 log units), on the low side; the measured number lies above the stated range.
By their numbers in this assay, from the lowest: compounds 3 and 1 (each within the scatter of the next); then compounds 2 and 4 (each within the scatter of the next).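

In this assay, the chloro group's presence on the aromatic ring does not settle the outcome, since exchanging 3-chlorophenyl for 4-chlorophenyl on the amide-type nitrogen, with the same atoms joined differently, gives a clear change (a 7.2-fold higher number from compound 3 to compound 4 (0.86 log units; beyond the scatter)). Chloro in place of hydrogen therefore has no single size in this series: one chlorinated compound stays within the scatter of the parent (a 1.9-fold lower number from compound 1 to compound 3 (0.28 log units; within the scatter)), while the other moves beyond it (a 3.8-fold higher number from compound 1 to compound 4 (0.58 log units; beyond the scatter)). Keeping an aromatic ring directly on the amide-type nitrogen also does not by itself hold the number at the low end, as 4-chlorophenyl and benzyl cannot be told apart here (a 1.1-fold higher number from compound 2 to compound 4 (0.06 log units; within the scatter)). Nothing available explains the gap between the two chlorophenyl groups.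

From the compounds shown here alone, it remains open whether this split belongs to chloro alone or would recur with another substituent, as in the pair 3-methoxyphenyl and 4-methoxyphenyl. Going by these compounds, the result for 2-chlorophenyl also remains open, so the three chlorophenyl groups cannot yet be compared on the shared core.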